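Swapping a sulfonamide arm for a second methoxyanilino arm

The compounds below may be only part of what the source reports. "The series", "measured", "known", "first", "only" and "open" are said of these compounds alone.

Among the compounds with values here, compound 1 `COc1ccc(Nc2cc(C)nc(Nc3ccc(NS(=O)(=O)c4ccccc4Cl)cc3)n2)cc1` is the only member of this small set with an actual number: in a functional assay on MDA-MB-231 cells (Homo sapiens) for antiproliferative activity, read by MTT assay (a lower number here means a stronger inhibitor, a higher number a weaker inhibitor), compound 1 gives 15300 nM. Compound 2 `COc1ccc(Nc2cc(C)nc(Nc3ccc(NS(=O)(=O)c4c(Cl)cc(C)cc4OC)cc3)n2)cc1` reaches only a limit of the assay, > 50000 nM. The step of an at least 3.2-fold higher number from compound 1 to compound 2 (0.51 log units; beyond the scatter) is therefore known only as a lower bound because the limit of > 50000 nM in this assay, at which 1 of the 2 values shown sits, caps what the assay can report. Compound 3 `COc1ccc(Nc2ccc(Nc3nc(C)cc(Nc4ccc(OC)cc4)n3)cc2)cc1` changes compound 1 differently: 4-methoxyphenyl in place of (2-chlorophenyl)sulfonyl on a nitrogen on an aromatic ring. Within the data shown here, the one measured step altered the ring on the sulfonyl sulfur while keeping the sulfonamide; it gives no direct guidance for removing the sulfonamide altogether, so no step beyond the scatter is predicted in either direction. The expectation for compound 3 is a value close to that of compound 1, with a step of a 1.3-fold higher number from compound 1 to compound 3 (0.12 log units; within the scatter), and an estimate of 20000 nM spanning 6000 nM to 50000 nM.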

Compound 3, half-maximal inhibitory concentration: > 50000 nM
Compound 3: only a limit was reported; the forecaster's own chance of this, stated with the estimate: 30%; middle value at least 2.5-fold (0.39 log units) away from the limit.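

The earlier step changed only the ring on the sulfonyl sulfur, whereas this change replaces the whole (2-chlorophenyl)sulfonyl group on the nitrogen with 4-methoxyphenyl, and it gives an at least 3.2-fold higher number from compound 1 to compound 3 (0.51 log units; beyond the scatter) in this assay. So at this nitrogen, the 4-methoxyphenyl group does not match the (2-chlorophenyl)sulfonyl group of compound 1, which remains the only compound here with an actual number. Compound 3 gives only a limit, and its step is a lower bound because of the cap on what can be reported: the limit of > 50000 nM in this assay, at which 2 of the 3 values shown sit.

Compound 2 and compound 3 both stop at that limit, so the step between them cannot be read. From the compounds shown here alone, it also remains open whether the sulfonyl link or the chlorinated ring matters more, a question that a methylsulfonyl or acetyl group on this nitrogen could help to separate.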